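The source may hold more compounds than are shown below. What is called first, only, known or untested is meant among the compounds shown, and "the series" means these compounds.

Measured compounds:
- compound 1 `Nc1ncnc2c1nc(NCCCCNC(=O)CI)n2[C@@H]1O[C@H](COP(=O)(O)OP(=O)(O)OP(=O)(O)O)[C@@H](O)[C@H]1O`: 0%
- compound 2 `CN(CCCCN(C)c1ncnc2c1ncn2[C@@H]1O[C@H](COP(=O)(O)OP(=O)(O)OP(=O)(O)O)[C@@H](O)[C@H]1O)C(=O)CCCCCNC(=O)CI`: 0%

Series notes. In an assay on isolated protein for inhibition of hexokinase-1 (Rattus norvegicus), with a stated time of 6 h, tested at 10 mM (on this read-out lower numbers stand for less inhibition and higher numbers for more inhibition at the one concentration tested (going by the name of the read-out)), compound 1 gives 0% and stands level with compound 2 at the digits reported; compound 2 gives 0% in this assay, and the two values lie within the scatter of each other, so neither is to be ordered against the other. Among the measured compounds shown here, no pair of measured compounds that differ in a single place is available, hence no measured step can be read off for this series.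

Compound 3 `Nc1ncnc2c1nc(NCCCCCCCCNC(=O)CI)n2[C@@H]1O[C@H](COP(=O)(O)OP(=O)(O)OP(=O)(O)O)[C@@H](O)[C@H]1O` is the next member. It differs from compound 1 by 4-(((iodomethyl)carbonyl)amino)butyl in place of ((iodomethyl)carbonyl)amino on a saturated chain carbon, four bonds along the chain from a nitrogen on an aromatic ring. For the measured compounds named here, with no measured step to lean on, the expected step of no change at the digits printed from compound 1 to compound 3 (within the scatter) is none beyond the scatter, in no preferred direction. Compound 3 is therefore estimated to give 0% in this assay. The estimated range for compound 3 is expected to run from 0% to 10%.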

Compound 3, a percentage reported as inhibition, at one concentration (the size of the read-out at that concentration, not a potency): 0%
Compound 3: middle estimate and measured number agree at the digits printed, within the range that was stated.
By their numbers in this assay, from the lowest: compounds 1, 2 and 3 (each within the scatter of the next).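

Among the compounds shown here, the first measured step at this position, read in this assay, is no change at the digits printed from compound 1 to compound 3 (within the scatter) for 4-(((iodomethyl)carbonyl)amino)butyl in place of ((iodomethyl)carbonyl)amino on a saturated chain carbon, four bonds along the chain from a nitrogen on an aromatic ring. Adding to the chain at this place, with the ((iodomethyl)carbonyl)amino end kept, therefore gives no step beyond the scatter in this assay, and neither of the two chain lengths can be ordered against the other. Nothing at hand bears on why these two compounds read alike.

Still open, as far as these compounds go, is whether any change at this chain end gives a reading that departs from compound 1 in this assay, for instance a primary amine or a carboxylic acid in place of the ((iodomethyl)carbonyl)amino group. For the compounds shown here, a longer chain than the one in compound 3 is equally unresolved, so no trend with chain length can be stated from these compounds.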